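The source may hold more compounds than are shown below. What is called first, only, known or untested is meant among the compounds shown, and "the series" means these compounds.

Measured in a physicochemical assay, read by spectrophotometry, with a stated time of 30 min; on this read-out higher numbers stand for weaker inhibition and lower numbers for stronger inhibition:
compound 1 `O=C(CCc1nc2ccccc2c(=O)[nH]1)N/N=C/c1ccc(Cl)cc1`: 381000000 nM
compound 2 `COc1ccc(/C=N/NC(=O)CCCc2nc3ccccc3c(=O)[nH]2)cc1`: 247000000 nM
compound 3 `COc1cc(/C=N/NC(=O)CCCc2nc3ccccc3c(=O)[nH]2)ccc1O`: 236000000 nM

On these numbers compound 1 sits at the top of the three, yet its gaps to compound 2 and to compound 3 both fall within the usual scatter, so the three compounds are not separated from one another. Going by the values given here, the only step between measured compounds, a 1.0-fold lower number from compound 2 to compound 3 (0.02 log units; within the scatter), also altered the aromatic ring on the carbon with a double bond to nitrogen and left the number where it was. Compound 4 `O=C(CCc1nc2ccccc2c(=O)[nH]1)N/N=C/c1ccccc1` differs from compound 1 by hydrogen in place of chloro on an aromatic carbon. Among the compounds with values here, no measured step concerns a chloro group; the one comparable ring change was flat. Compound 4 is therefore expected to give 381000000 nM (range 150000000 nM to 950000000 nM) in this assay. The expected step is no change at the digits printed from compound 1 to compound 4 (within the scatter), nothing beyond the scatter.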

Compound 4, half-maximal inhibitory concentration: 734000000 nM
Estimate against measurement, compound 4: 1.9-fold (0.28 log units) below; the range from low to high includes it.
By their numbers in this assay, from the lowest: compounds 3, 2, 1 and 4 (each within the scatter of the next, the first and the last beyond it).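

In this assay, going by these compounds alone, the first step at this position reads a 1.9-fold higher number from compound 1 to compound 4 (0.28 log units; within the scatter) and so does not separate the two compounds. On an aromatic carbon para to a large group, 4-chlorophenyl and phenyl therefore cannot be told apart on these numbers, which extends the flat picture from the earlier ring change to the chloro group itself. No independent data bear on this result.

As far as these compounds go, whether an amine or a carboxylic acid in place of chloro would give a step beyond the scatter remains open. Also open, from the compounds shown here alone, is whether hydrogen in place of chloro reads the same with a different chain on the shared core.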